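The source may report more compounds than this note shows. Statements on the series, on what has been measured and on what is new or still open speak of the compounds shown alone.

Working notes on the series.

The measurements come from an assay on cells for inhibition of phosphatidylcholine:ceramide cholinephosphotransferase 2 (Homo sapiens), read by mass spectrometry, with stated times of 60 min and 30 min; on this read-out higher numbers stand for weaker inhibition and lower numbers for stronger inhibition. Compound 1 `CCOc1cc(CN(C)C(=O)c2c(OCCCC3CCN(C(=O)OC(C)(C)C)CC3)c3ccccc3n(C)c2=O)cc(OCC)c1` gives 380 nM in this assay. Against the other two measured compounds, compound 1 stands second highest of three. Compound 2 `CN(Cc1cc(C(F)(F)F)cc(C(F)(F)F)c1)C(=O)c1c(OCCCC2CCN(C(=O)OC(C)(C)C)CC2)c2ccccc2n(C)c1=O`, which carries a bis(trifluoromethyl)phenyl group on the same core, gives 30 nM, a lower number than compound 1 and beyond the usual scatter. Compound 3 `CN(Cc1cc(C(F)(F)F)cc(C(F)(F)F)c1)C(=O)c1c(N2CCCCC2)c2ccccc2n(C)c1=O`, which swaps the ether chain for a piperidine on the core, gives 11000 nM, a higher number than compound 1 and again beyond the scatter. For the measured compounds named here, nothing measured in the set changes the alkoxy groups on the benzyl ring alone, so no direct precedent exists for that change.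

Compound 4 `COc1cc(CN(C)C(=O)c2c(OCCCC3CCN(C(=O)OC(C)(C)C)CC3)c3ccccc3n(C)c2=O)cc(OC)c1` differs from compound 1 in one place: 3,5-dimethoxyphenyl in place of 3,5-diethoxyphenyl on a saturated chain carbon bound to an amide-type nitrogen. Going by the values given here, the change is small in size and keeps the count of hydrogen-bond acceptors, and no measured pair shows how this assay responds to it. The step from compound 1 to compound 4 is therefore expected to be modest, with a slight lean toward a higher number, and plausibly within the scatter: a 1.4-fold higher number from compound 1 to compound 4 (0.16 log units; within the scatter). Compound 4 is estimated at 550 nM, with a range from 180 nM to 1700 nM.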

Compound 4, half-maximal inhibitory concentration in the phosphatidylcholine:ceramide cholinephosphotransferase 2 assay: 91 nM
For compound 4 the middle estimate is 6.0-fold (0.78 log units) above the measured one; measured number below the stated range.
By their numbers in the phosphatidylcholine:ceramide cholinephosphotransferase 2 assay, from the lowest: compound 2; then compound 4; then compound 1; then compound 3.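

For the compounds shown here, replacing 3,5-diethoxyphenyl with 3,5-dimethoxyphenyl on a saturated chain carbon bound to an amide-type nitrogen gives the first one-place comparison, and in the phosphatidylcholine:ceramide cholinephosphotransferase 2 assay it reads a 4.2-fold lower number from compound 1 to compound 4 (0.62 log units; beyond the scatter), so this position responds to a change that keeps the count of hydrogen-bond acceptors. In a physicochemical assay for solubility, read by LC-MS, at pH 6.8 (on this read-out higher numbers stand for higher solubility and lower numbers for lower solubility), compound 1 gives < 0.08 ug/mL, which is a limit of the assay and not a number. In the physicochemical assay compound 4 gives 1.8 ug/mL, and the same change therefore also moves this second read-out, with lower inhibition numbers and higher solubility numbers arriving together in this one pair: an at least 22-fold higher number from compound 1 to compound 4 (1.35 log units; beyond the scatter).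

As far as these compounds go, a single pair sets no trend with alkoxy chain length, so it remains open whether the number in the phosphatidylcholine:ceramide cholinephosphotransferase 2 assay would keep falling with a hydroxy group in place of each methoxy group. Also open, from the compounds shown here alone, is how either read-out would respond to a dimethylamino group or a carboxylic acid on the same phenyl ring.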